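Halogen swap on the oxane-core phenoxy compound

The compounds below may be only part of what the source reports. "The series", "measured", "known", "first", "only" and "open" are said of these compounds alone.

Compound 1 `NC1=NC2(CCOCC2)N(OCCCOc2ccc(Cl)cc2)C(N)=N1` gives 690 nM in a functional assay on HCT-116 cells (Homo sapiens) for antiproliferative activity, read by MTT assay, with a stated time of 72 h (on this read-out higher numbers stand for weaker inhibition and lower numbers for stronger inhibition), the highest of the three numbers recorded. Compound 2 `NC1=NC2(CCSCC2)N(OCCCOc2ccccc2Br)C(N)=N1` gives 1 nM and compound 3 `NC1=NC2(CCSCC2)N(OCCCOc2ccccc2Cl)C(N)=N1` gives 1 nM; both carry a different core from compound 1 and place the halogen elsewhere on the ring, so their distance from compound 1 is read from the values alone and is not assigned to one change.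

Compound 4 `NC1=NC2(CCOCC2)N(OCCCOc2ccc(Br)cc2)C(N)=N1` differs from compound 1 by bromo in place of chloro on an aromatic carbon. Among the measured compounds shown here, the one measured step of the same kind, run in the opposite direction, is no change at the digits printed from compound 2 to compound 3 (within the scatter). For the measured compounds named here, it sits on the other core, so it bears only loosely on the present step, but it is the sole guide available, and the change itself adds or removes nothing that is counted beyond the halogen.

On that basis no movement beyond the scatter is expected from compound 1 to compound 4, no change at the digits printed from compound 1 to compound 4 (within the scatter). Compound 4 is therefore estimated at 690 nM, with a range from 300 nM to 1600 nM.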

Compound 4, half-maximal inhibitory concentration: 320 nM
For compound 4 the middle estimate is 2.2-fold (0.33 log units) above the measured one; the range from low to high includes it.
By their numbers in this assay, from the lowest: compounds 2 and 3 (each within the scatter of the next); then compound 4; then compound 1.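

With the halogen para to a large group on the core of compound 1, bromo in place of chloro gives a 2.2-fold lower number from compound 1 to compound 4 (0.33 log units; beyond the scatter) in this assay. This position therefore shows a modest response to the halogen swap, whereas the earlier pair on the other core showed no change at the digits printed. The two steps still do not set the cores apart: the same change on two cores in this assay, no change at the digits printed (within the scatter) from compound 2 to compound 3 and a 2.2-fold higher number (0.33 log units; beyond the scatter) from compound 4 to compound 1, 2.2-fold (0.33 log units) apart, within the scatter of two such steps

The compounds shown leave open how this position responds to a fluoro, methoxy, nitrile or amine group, so two halogens are all that define it so far. The large distance between this pair and compound 2 or compound 3 also remains unassigned, as core and halogen place differ together.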